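The source may hold more compounds than are shown below. What is called first, only, known or untested is meant among the compounds shown, and "the series" means these compounds.

Working notes on a small set of aminofluorobenzoyl hydrazides carrying a chlorinated aryl ring.

Compound 1 `Nc1cccc(F)c1C(=O)NNc1cccc(Cl)c1` is the parent of the pair under discussion. In a toxicity assay on Vero cells (Chlorocebus sabaeus) for cytotoxicity, read by colorimetric assay and MTT assay, with a stated time of 72 h (on this read-out lower numbers stand for higher toxicity in this test and higher numbers for lower toxicity in this test), compound 1 gives > 1800000 nM, which is a limit of the assay and not a number. Compound 2 `Nc1cccc(F)c1C(=O)NNc1ccc(Cl)cc1` has the same atoms as compound 1 joined differently; the difference between the two cores is not broken down here. In this assay compound 2 gives 373000 nM. Compound 3 `Nc1cccc(F)c1C(=O)NNc1ccc(Cl)cc1Cl` adds to compound 2 a chloro group (chloro in place of hydrogen on an aromatic carbon). In this assay compound 3 gives 1040000 nM. Going by the values given here, this step, a 2.8-fold higher number from compound 2 to compound 3 (0.45 log units; beyond the scatter), is the only measured change of its kind in the set.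

Compound 4 `Nc1cccc(F)c1C(=O)NNc1cc(Cl)ccc1Cl` is not yet measured. It is made from compound 1 by the same kind of change (chloro in place of hydrogen on an aromatic carbon); the two places differ only in that the entering chloro of compound 4 sits para to a chloro group, whereas that of compound 3 sits meta to a chloro group.

For compound 4 the expected step, set beside a 2.8-fold higher number from compound 2 to compound 3 (0.45 log units; beyond the scatter), is a step that the limit leaves unreadable from compound 1 to compound 4; this rests on compound 1 already standing at the limit of > 1800000 nM in this assay, at which 1 of the 3 values shown sits, and on the measured step having raised the number in this assay. Compound 4 is therefore expected to give about 2500000 nM in this assay, with a likely range of 1200000 nM to 5000000 nM, and a fair chance that only a limit is reported again.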

Compound 4, half-maximal cytotoxic concentration: > 1800000 nM
Compound 4: a limit, no number (the forecaster's own chance of this, stated with the estimate: 70%); the middle value does not contradict the limit.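

In this assay compound 4 gives > 1800000 nM, a limit of the assay and not a number. Compound 1 also stands at a limit, so no step from compound 1 to compound 4 can be read: the limit of > 1800000 nM in this assay, at which 2 of the 4 values shown sit.

Left open is whether the step of a 2.8-fold higher number from compound 2 to compound 3 (0.45 log units; beyond the scatter) has any counterpart when chloro enters compound 1 to give compound 4.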